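Working notes: expectation for compound 4

This account rests on a few compounds, and the source may have more. Where it says the series, first, only, none or still open, it means among the compounds named here.

Compound 1 `O=C(Nc1cccc(-c2nc3ccccc3s2)c1)c1cnccc1Cl`, in an ADME assay on HepG2 cells (Homo sapiens) for inhibition, with a stated time of 72 h (on this read-out lower numbers stand for an effect already at smaller amounts and higher numbers for an effect only at larger amounts of compound), a limit: > 25000 nM.
Compound 2 `Cc1ccc(-c2nc3ccccc3s2)cc1NC(=O)c1cnccc1Cl`, this assay, a limit: > 25000 nM.
Compound 3 `COc1ccc(-c2nc3ccccc3s2)cc1NC(=O)c1cnccc1Cl`, this assay, a limit: > 25000 nM.

Compound 3 stands at the limit of this assay, as do the two other compounds (the limit of > 25000 nM in this assay, at which 3 of the 3 values shown sit). The steps a step that the two limits leave unreadable from compound 1 to compound 2, a step that the two limits leave unreadable from compound 1 to compound 3 and a step that the two limits leave unreadable from compound 2 to compound 3 therefore show no readable size. Compound 4 `O=C(Nc1cc(-c2nc3ccccc3s2)ccc1F)c1cnccc1Cl` differs from compound 3 by fluoro in place of methoxy on an aromatic carbon. The three measured steps all vary the same aromatic carbon and bear on this change, but none gives a size, so no direction is expected beyond the scatter, and compound 4 is estimated to sit at the limit as well. The step from compound 3 to compound 4 is thus estimated as a step that the limit leaves unreadable from compound 3 to compound 4. Compound 4 is expected near 30000 nM, within 10000 nM to 100000 nM.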

Compound 4, half-maximal effective concentration: > 25000 nM
Compound 4 was reported as a limit; the forecaster's own chance of this, stated with the estimate: 90%; the middle value does not contradict the limit.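

No step from compound 1, compound 2 or compound 3 to compound 4 can be read in this assay, as all four values are limits: the limit of > 25000 nM in this assay, at which 4 of the 4 values shown sit.

The compounds shown leave open whether any group on this aromatic carbon changes the read-out at all.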